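Cytotoxicity notes: a chloro analogue of compound 3

The source may hold more compounds than are shown below. What is called first, only, known or untested is meant among the compounds shown, and "the series" means these compounds.

Compound 3 `CCOC(=O)c1c(-c2cccc(OC)c2)[nH]c2cc(OC)ccc2c1=O` is the reference point. In an ADME assay on BJ cells (Homo sapiens) for cytotoxicity, read by luminescence, with a stated time of 72 h (a lower number here means that less compound is needed, a higher number that more compound is needed for the effect), compound 3 gives only a limit, > 21500 nM. Compound 1 `CCOC(=O)c1c(-c2cc(F)cc(OC)c2)[nH]c2cc(OC)ccc2c1=O` likewise gives a limit in this assay, > 21500 nM. Compound 2 `CCOC(=O)c1c(-c2cccc(-c3ccccc3)c2)[nH]c2cc(OC)ccc2c1=O` also gives a limit in this assay, > 21500 nM. All three sit at the limit of > 21500 nM in this assay, at which 3 of the 3 values shown sit, so the step that the two limits leave unreadable from compound 1 to compound 3 and the step that the two limits leave unreadable from compound 2 to compound 3 cannot be read. Compound 4 `CCOC(=O)c1c(-c2cccc(Cl)c2)[nH]c2cc(OC)ccc2c1=O` differs from compound 3 by chloro in place of methoxy on an aromatic carbon. Among the compounds with values here, no measured step bears on this exchange, and the two steps that exist are unreadable, so the expectation rests on the shared limit alone. In this assay the step that the limit leaves unreadable from compound 3 to compound 4 is expected to stay hidden beneath that limit. Compound 4 is therefore estimated at 25000 nM, within 10000 nM to 60000 nM.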

Compound 4, half-maximal effective concentration: > 21500 nM
Compound 4: only a limit was reported; the forecaster's own chance of this, stated with the estimate: 85%; the middle value lies beyond the limit too.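

Compound 4 gives only a limit in this assay, > 21500 nM. Its steps from compound 1, compound 2 and compound 3 therefore cannot be read: the limit of > 21500 nM in this assay, at which 4 of the 4 values shown sit.

The compounds shown leave open whether any of the four differs from another in this assay, and which exchange, if any, would yield a measurable value.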